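Replacing the nitro group on a weak ATM inhibitor

The source may hold more compounds than are shown below. What is called first, only, known or untested is meant among the compounds shown, and "the series" means these compounds.

Among the measured compounds shown here, compound 1 `COc1cc2ncnc(-n3nc(-c4ccccn4)nc3N)c2cc1[N+](=O)[O-]` is the only compound here with a numerical result: in an assay on MCF7 cells for inhibition of Serine-protein kinase ATM (Homo sapiens), read by immunofluorescence, with a stated time of 1 h (on this read-out lower numbers stand for stronger inhibition and higher numbers for weaker inhibition), compound 1 gives 31100 nM. Compound 2 `Nc1nc(-c2ccccn2)nn1-c1ncnc2cc(N3CCNCC3)c([N+](=O)[O-])cc12` reaches only the assay limit, giving > 40000 nM in this assay. For the measured compounds named here, the one measured step, an at least 1.2-fold higher number from compound 1 to compound 2 (0.10 log units; that floor lies within the scatter), concerns the methoxy group, not the nitro, so it does not bear on the change to compound 3 `COc1cc2ncnc(-n3nc(-c4ccccn4)nc3N)c2cc1OCCCN1CC(C)OC(C)C1`, namely (3-(2,6-dimethylmorpholin-4-yl)propoxy in place of nitro on an aromatic carbon). Going by the values given here, with no comparable step measured, the size and direction of a 3.1-fold lower number from compound 1 to compound 3 (0.49 log units; beyond the scatter) is an estimate with wide uncertainty. Compound 3 is expected to give 10000 nM in this assay, within 1000 nM to 40000 nM.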

Compound 3, half-maximal inhibitory concentration: 1600 nM
Compound 3: middle estimate off by 6.3-fold (0.80 log units), on the high side, and the stated range covers the measured number.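

At this position, ortho to a methoxy group, the nitro group is not required for the activity seen: replacing it with 3-(2,6-dimethylmorpholin-4-yl)propoxy gives a 19-fold lower number from compound 1 to compound 3 (1.29 log units; beyond the scatter) in this assay. This is the only step shown that lies beyond the scatter, and it shows that this position accepts a much larger group ending in a six-membered non-aromatic ring. The data shown give no reason for the gain.

From the compounds shown here alone, it remains open which part of the new group matters, the propoxy chain or the dimethylmorpholine ring. A shorter ethoxy chain or an unsubstituted morpholine at this position would help separate the two.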